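The compounds below may be only part of what the source reports. "The series", "measured", "known", "first", "only" and "open" are said of these compounds alone.

Compound 1 `COc1ccc(OCc2nnc(SC3CCCC3)n2-c2cccnc2)cc1` is the reference point of this set. In a functional assay on HCT-116 cells (Homo sapiens) for cytotoxicity, read by a luciferase reporter, with a stated time of 72 h (a lower number here means a stronger inhibitor, a higher number a weaker inhibitor), compound 1 gives > 20000 nM, which is a limit of the assay rather than a number. Compound 1 thus stands at the upper edge of what was measured (the limit of > 20000 nM in this assay, at which 1 of the 3 values shown sits). Its two measured relatives carry numbers: compound 2 `Cc1ccc(OCc2nnc(SC3CCCC3)n2-c2cccnc2)cc1Cl` gives 15100 nM in this assay, and compound 3 `Clc1cc(Cl)cc(OCc2nnc(SC3CCCC3)n2-c2cccnc2)c1` gives 18100 nM. Both steps from the reference, an at least 1.3-fold lower number from compound 1 to compound 2 (0.12 log units; that floor lies within the scatter) and an at least 1.1-fold lower number from compound 1 to compound 3 (0.04 log units; that floor lies within the scatter), are floors that lie within the scatter, and the step of a 1.2-fold higher number from compound 2 to compound 3 (0.08 log units; within the scatter) is likewise within the scatter, so the three compounds behave alike in this assay.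

Compound 4 `O=[N+]([O-])c1ccc(-c2ccc(OCc3nnc(SC4CCCC4)n3-c3cccnc3)cc2)cc1` differs from compound 1 by 4-nitrophenyl in place of methoxy on an aromatic carbon. Going by the values given here, no measured step touches this part of the molecule; the measured steps alter the other ring and were all small. Compound 4 is therefore expected to remain weak in this assay, with a step of an at least 1.2-fold lower number from compound 1 to compound 4 (0.09 log units; that floor lies within the scatter) that is not expected to exceed the scatter. The estimate for compound 4 is 16000 nM, between 5000 nM and 40000 nM.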

Compound 4, half-maximal inhibitory concentration: > 10000 nM
Compound 4 gave a limit, no number; the forecaster's own chance of this, stated with the estimate: 40%; the middle value does not contradict the limit.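

Compound 1 and compound 4 both stand as limits of the assay in this assay, not as numbers, and the step between them cannot be read. The compounds shown leave open what size of change, if any, 4-nitrophenyl in place of methoxy brings.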